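Notes on compound 3 and the untested compound 4

A few compounds are considered here, and "the series" means these few. Any claim that something is new, unique, unknown or untested is made for them only; others in the source may bear on it.

Measured compounds in a functional assay on Jurkat cells (Homo sapiens) for inhibition, read by MTT assay, with a stated time of 72 h; on this read-out higher numbers stand for weaker inhibition of growth and lower numbers for stronger inhibition of growth: compound 1 `COC(=O)c1nc(C)n(-c2ccccc2)n1` gives > 100000 nM, which is a limit of the assay and not a number. Compound 2 `COC(=O)c1nc(C)n(-c2ccc(C(F)(F)F)cc2)n1` gives 9100 nM. Compound 3 `COC(=O)c1nc(C(C)C)n(-c2ccc(F)cc2)n1` gives > 100000 nM, again a limit of the assay and not a number.

Compound 3 thus stands at the limit of > 100000 nM in this assay, at which 2 of the 3 values shown sit, with no numerical value to anchor it. For the measured compounds named here, the only step measured between single-change neighbours is an at least 10-fold lower number from compound 1 to compound 2 (1.04 log units; beyond the scatter), a change on an aromatic carbon of the phenyl ring. Going by the values given here, compound 4 `COC(=O)c1nc(C2CCCCC2)n(-c2ccc(F)cc2)n1` differs from compound 3 by cyclohexyl in place of isopropyl on an aromatic carbon, a change at a different place, and no measured step bears on it directly. The measured step offers no guide for the isopropyl-to-cyclohexyl exchange, so no direction can be derived. Compound 4 is therefore expected to remain near the limit, with the step that the limit leaves unreadable from compound 3 to compound 4 estimated as none beyond the scatter. The estimate for compound 4 in this assay is 120000 nM, with a range from 30000 nM to 500000 nM.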

Compound 4, concentration for 50% growth inhibition: > 100000 nM
Compound 4: a limit, no number; the forecaster's own chance of this, stated with the estimate: 70%; the middle value lies beyond the limit too.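

For the compounds shown here, no step from compound 3 to compound 4 can be read in this assay, since both values are limits of the assay and not numbers: the limit of > 100000 nM in this assay, at which 3 of the 4 values shown sit. From the compounds shown here alone, whether cyclohexyl in place of isopropyl alters growth inhibition at all remains open.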